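From hydroxy to methoxy on compound 2

The source may hold more compounds than are shown below. What is called first, only, known or untested is meant among the compounds shown, and "the series" means these compounds.

Compound 1 `CCCSc1nc(N/N=C/c2ccc(C)cc2)c2nnn(Cc3ccccc3)c2n1` gives > 64000 nM as a limit
Compound 2 `CCCSc1nc(N/N=C(\C)c2ccc(O)cc2)c2nnn(Cc3ccccc3)c2n1` gives 21600 nM
Compound 3 `CCCSc1nc(N/N=C/c2ccc(Cl)cc2)c2nnn(Cc3ccccc3)c2n1` gives > 64000 nM as a limit

Within the data shown here, in a functional assay on MCF7 cells (Homo sapiens) for antiproliferative activity, read by MTT assay, with a stated time of 72 h (on this read-out higher numbers stand for weaker inhibition and lower numbers for stronger inhibition), compound 2 gives 21600 nM, the only number among the three. The other two values stand at the limit of > 64000 nM in this assay, at which 2 of the 3 values shown sit.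

Compound 4 `CCCSc1nc(N/N=C(\C)c2ccc(OC)cc2)c2nnn(Cc3ccccc3)c2n1` differs from compound 2 by one change: methyl in place of hydrogen on an oxygen on an aromatic ring. This turns hydroxy into methoxy. Among the measured compounds shown here, no measured step makes exactly this change.

The nearest evidence is an at least 2.9-fold lower number from compound 1 to compound 2 (0.47 log units; beyond the scatter) and an at least 2.9-fold higher number from compound 2 to compound 3 (0.47 log units; beyond the scatter). Both lie beyond the scatter, but each is set by a limit and each exchanges a larger group than the hydroxy alone. The third step, a step that the two limits leave unreadable from compound 1 to compound 3, adds nothing.

Compound 4 also gives up the hydroxy, and compound 3 without it shows an at least 2.9-fold higher number from compound 2 to compound 3 (0.47 log units; beyond the scatter), so a modest move toward a higher number is expected. The expected change is a 1.6-fold higher number from compound 2 to compound 4 (0.21 log units; within the scatter). For compound 4 the estimated value is 35000 nM, within an expected range of 15000 nM to 64000 nM.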

Compound 4, half-maximal inhibitory concentration: > 64000 nM
Compound 4 gave a limit, no number; the forecaster's own chance of this, stated with the estimate: 30%; middle value at least 1.8-fold (0.26 log units) away from the limit.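

In this assay, methyl in place of hydrogen on an oxygen on an aromatic ring gives an at least 2.9-fold higher number from compound 2 to compound 4 (0.47 log units; beyond the scatter), the only step shown that makes this change alone. The earlier steps shown here each exchanged a larger group, so this one ties the loss to the hydroxy itself: turning 4-hydroxyphenyl into 4-methoxyphenyl is enough to move the value beyond the scatter. The full size of the step cannot be read, as the value of compound 4 is a limit and not a number, and compound 2 alone keeps a number: the limit of > 64000 nM in this assay, at which 3 of the 4 values shown sit.

What the compounds shown leave open is whether the free hydroxy is needed as such or could be replaced. An amine or a carboxylic acid at this place on the ring would test that, and neither stands among these compounds.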